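Swapping a fused bicyclic amine for a dimethylmorpholine ring

A few compounds are considered here, and "the series" means these few. Any claim that something is new, unique, unknown or untested is made for them only; others in the source may bear on it.

Of the compounds shown here, three sharing one core have been measured in a physicochemical assay for lipophilicity, at pH 7.4; a higher number here means a more lipophilic compound, a lower number a more polar compound. Compound 1 `CN1CC2(C1)CN(c1ccc(OCc3ccccc3)c(C(=O)Nc3ccnnc3)c1)C2` gives 2 and compound 2 `CN1CCC(c2ccc(OCc3ccccc3)c(C(=O)Nc3ccnnc3)c2)CC1` gives 2.3; the step of a number 0.30 log units higher from compound 1 to compound 2 (within the scatter) is within the scatter. Compound 3 `O=C(Nc1ccnnc1)c1cc(N2C[C@H]3COC[C@H]3C2)ccc1OCc1ccccc1` gives 4.5, the highest of the three, with a number 2.50 log units higher from compound 1 to compound 3 (beyond the scatter) and a number 2.20 log units higher from compound 2 to compound 3 (beyond the scatter) both large and beyond the scatter. In both of those steps a group holding two nitrogens or one nitrogen gives way to a group holding one nitrogen and one oxygen.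

Compound 4 `C[C@@H]1CN(c2ccc(OCc3ccccc3)c(C(=O)Nc3ccnnc3)c2)C[C@H](C)O1` is not yet measured. It differs from compound 3 in one place: a group of 8 heavy atoms (6 carbon, 1 nitrogen, 1 oxygen; one six-membered non-aromatic ring with 2 hetero atoms) in place of a group of 8 heavy atoms (6 carbon, 1 nitrogen, 1 oxygen; 2 five-membered non-aromatic rings with 1 hetero atom each), on an aromatic carbon. Here the count of nitrogen, oxygen, donors and acceptors does not change, and no net charge appears or disappears, so neither of the large measured steps resembles this swap; they bear on it only by placing compound 3 far above compounds 1 and 2. Among the measured compounds shown here, no measured pair isolates a move between two neutral rings of the same atom count. A step no larger than the scatter is therefore expected, in no firm direction. Compound 4 is estimated at 4.4, between 3.8 and 5, which means an expected step of a number 0.10 log units lower from compound 3 to compound 4 (within the scatter).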

Compound 4, distribution coefficient: 5.4
The estimate for compound 4 lay 1.00 log units below the measured number; the whole stated range lies below it.
By their numbers in this assay, from the lowest: compounds 1 and 2 (each within the scatter of the next); then compound 3; then compound 4.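

In this assay, among the compounds shown here, the earlier compounds left unsettled whether a move between two ring groups with the same heavy-atom count, the same hydrogen-bond donor and acceptor counts and no net charge could matter on this aromatic carbon, para to a benzyloxy group; the 2,6-dimethylmorpholin-4-yl group shows that it can, with a number 0.90 log units higher from compound 3 to compound 4 (beyond the scatter). Matching counts of carbon, nitrogen and oxygen therefore did not fix the number at this position, and compound 4 now stands highest of the four, with a number 3.10 log units higher from compound 2 to compound 4 (beyond the scatter) and a number 3.40 log units higher from compound 1 to compound 4 (beyond the scatter). No measurement at hand explains the difference between these ring groups.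

On these data alone, what remains open is how much of the step from the fused ring group belongs to the six-membered ring itself and how much to its two methyl groups, a question that an unsubstituted morpholin-4-yl group at the same place would address. Also open, as far as these compounds go, is whether a ring with a single methyl group, or the other stereochemical arrangement of the two methyl groups, would give a similar number.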